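Working notes: from compound 2 to compound 3

A few compounds are considered here, and "the series" means these few. Any claim that something is new, unique, unknown or untested is made for them only; others in the source may bear on it.

In a functional assay on K562/A02 cells (Homo sapiens) for antiproliferative activity, read by MTT assay (a higher number here means a weaker inhibitor, a lower number a stronger inhibitor), compound 1 `COc1cccc(/C(C)=N/NC(=S)NCCCCCC(=O)NO)c1` gives 1890 nM and compound 2 `C/C(=N\NC(=S)NCCCCCC(=O)NO)c1ccc(F)cc1` gives 1020 nM, so compound 2 stands level with compound 1 within the scatter. Compound 3 `C/C(=N\NC(=S)NCCCCCC(=O)NO)c1cccc(C)c1` carries the change 3-methylphenyl in place of 4-fluorophenyl on a carbon with a double bond to nitrogen. Among the compounds with values here, the only measured step, a 1.9-fold lower number from compound 1 to compound 2 (0.27 log units; within the scatter), also exchanged one substituted phenyl for another, so no step beyond the scatter is expected in this assay. The expected step is a 1.4-fold higher number from compound 2 to compound 3 (0.14 log units; within the scatter). For compound 3 the estimate is 1400 nM, with an expected range of 650 nM to 3000 nM.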

Compound 3, half-maximal inhibitory concentration: 3570 nM
Compound 3: the middle estimate sits 2.6-fold (0.41 log units) below what was measured; measured number above the stated range.
By their numbers in this assay, from the lowest: compounds 2, 1 and 3 (each within the scatter of the next, the first and the last beyond it).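

In this assay, exchanging one substituted phenyl for another on the carbon with a double bond to nitrogen now gives a step beyond the scatter (a 3.5-fold higher number from compound 2 to compound 3 (0.54 log units; beyond the scatter)), so the choice of phenyl group at this place can matter, if modestly. Methyl in place of methoxy on an aromatic carbon stays within the scatter (a 1.9-fold higher number from compound 1 to compound 3 (0.28 log units; within the scatter)). Nothing available accounts for the step.

The step from 4-fluorophenyl to 3-methylphenyl changes both the substituent and its ring position, so 4-methylphenyl or 3-fluorophenyl would be needed to separate the two. From the compounds shown here alone, how an amine or a carboxylic acid on the phenyl ring would read here remains open.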